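The compounds below may be only part of what the source reports. "The series", "measured", "known", "first", "only" and "open" are said of these compounds alone.

Measured so far:
compound 1 `S=c1[nH]nc(-c2ccccc2)n1CCSCc1ccccc1` — 152000 nM
compound 2 `Cc1ccccc1-c1n[nH]c(=S)n1CCSCc1ccccc1` — 121000 nM

In a functional assay on HeLa cells (Homo sapiens) for cytotoxicity, read by LDH release, with a stated time of 24 h (on this read-out lower numbers stand for stronger inhibition and higher numbers for weaker inhibition), compound 1 gives 152000 nM and compound 2 gives 121000 nM; the step of a 1.3-fold lower number from compound 1 to compound 2 (0.10 log units; within the scatter) is within the scatter, so compound 2 stands together with compound 1 on this assay. Compound 3 `Cn1cccc1-c1n[nH]c(=S)n1CCSCc1ccccc1` differs from compound 2 by 1-methyl-1H-pyrrol-2-yl in place of 2-methylphenyl on an aromatic carbon. Going by the values given here, the only measured step concerns methyl in place of hydrogen on an aromatic carbon and does not address an aryl ring exchange, so the data give no direction. Compound 3 is expected near compound 2, with an estimated step of a 1.0-fold lower number from compound 2 to compound 3 (0.00 log units; within the scatter). The estimate for compound 3 is 120000 nM, range 50000 nM to 300000 nM.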

Compound 3, half-maximal inhibitory concentration: > 250000 nM
Compound 3: a limit, no number; the forecaster's own chance of this, stated with the estimate: 15%; middle value at least 2.0-fold (0.31 log units) away from the limit.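

In this assay compound 3 gives > 250000 nM, a limit and not a number. Unlike the methyl step, the aryl exchange at this position moves the read-out beyond the scatter, with 1-methyl-1H-pyrrol-2-yl in place of 2-methylphenyl giving an at least 2.0-fold higher number from compound 2 to compound 3 (0.31 log units; beyond the scatter), while the floor against phenyl, an at least 1.6-fold higher number from compound 1 to compound 3 (0.21 log units; that floor lies within the scatter), does not by itself separate the two. The full size of either step cannot be read from this result: the limit of > 250000 nM in this assay, at which 1 of the 3 values shown sits.

Still open, from the compounds shown here alone, is how an amine or a carboxylic acid on the phenyl group of compound 1 would read in this assay.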